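The source may report more compounds than this note shows. Statements on the series, on what has been measured and on what is new or still open speak of the compounds shown alone.

Compound 1 `COc1cc2ncnc(Nc3cccc(C#N)c3)c2cc1OC`: "not active" (no number reported)
Compound 2 `COc1cc2ncnc(Nc3cccc(C(=O)O)c3)c2cc1OC`: 32%

In an assay on isolated protein for inhibition of vascular endothelial growth factor receptor 1 (Homo sapiens), read by ELISA, with a stated time of 20 min, tested at 1 uM (on this read-out higher numbers stand for more inhibition at the one concentration tested (going by the name of the read-out) and lower numbers for less inhibition), compound 1 is reported as "not active" (no number reported), so no number stands beside it. Compound 2, in this assay, gives 32%, which is the only number shown among the measured compounds; it therefore has no measured neighbour against which its standing could be compared. Compound 3 `COc1cc2ncnc(Nc3cccc(CO)c3)c2cc1OC` has not yet been measured. It differs from compound 2 in one place: hydroxymethyl in place of carboxy on an aromatic carbon. Among the measured compounds shown here, no step between two measured compounds that differ in one place is available, so the size of this change cannot be read off from the data and has to be guessed. A downward step, a number 17 percentage points lower from compound 2 to compound 3 (beyond the scatter), is expected, larger than the usual scatter of this kind of measurement. The estimate for compound 3 in this assay is 15%, ranging from 0% to 38%.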

Compound 3, a percentage reported as inhibition, at one concentration (the size of the read-out at that concentration, not a potency): "not active" (no number reported)
The entry for compound 3 holds no number; there is nothing to compare the estimate with.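

In this assay, among the compounds shown here, compound 3 gives "not active" (no number reported), and with no number for it, no step from compound 2 to compound 3 can be read. Nothing measured here bears on this result. The compounds shown leave open how much swapping carboxy for hydroxymethyl changes inhibition.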